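Nitro in place of chloro on the hydrazone aryl ring

The source may report more compounds than this note shows. Statements on the series, on what has been measured and on what is new or still open speak of the compounds shown alone.

Compound 2 `Clc1ccc(NN=C(c2nc3ccccc3[nH]2)c2nc3ccccc3[nH]2)cc1` was tested in a functional assay on PC-3 cells (Homo sapiens) for cytotoxicity, read by MTT assay, with a stated time of 72 h (on this read-out higher numbers stand for weaker inhibition and lower numbers for stronger inhibition), and gave 250000 nM. Within the data shown here, its only measured neighbour, compound 1 `c1ccc(NN=C(c2nc3ccccc3[nH]2)c2nc3ccccc3[nH]2)cc1`, gives 248000 nM in this assay, so the two numbers lie within the scatter of each other and neither can be ranked against the other. Among the measured compounds shown here, the one step recorded so far, a 1.0-fold higher number from compound 1 to compound 2 (0.00 log units; within the scatter), therefore shows no effect of the substituent at this ring position beyond the scatter.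

Compound 3 `O=[N+]([O-])c1ccc(NN=C(c2nc3ccccc3[nH]2)c2nc3ccccc3[nH]2)cc1` differs from compound 2 in one place: nitro in place of chloro on an aromatic carbon. For the measured compounds named here, the single step that bears on this position is a 1.0-fold higher number from compound 1 to compound 2 (0.00 log units; within the scatter), which was flat. On that basis the step from compound 2 to compound 3 is expected to be no change at the digits printed from compound 2 to compound 3 (within the scatter), with no change beyond the scatter. Compound 3 is accordingly estimated at 250000 nM in this assay, within a range from 100000 nM to 600000 nM.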

Compound 3, half-maximal inhibitory concentration: 218000 nM
Beside the measured number, compound 3's estimate is 1.1-fold (0.06 log units) above it; the range from low to high includes it.
By their numbers in this assay, from the lowest: compounds 3, 1 and 2 (each within the scatter of the next).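

In this assay, nitro brings 3 heavy atoms and 2 hydrogen-bond acceptors to this aromatic carbon, para to a large group, where chloro has 1 heavy atom and no acceptor, yet the change gives a 1.1-fold lower number from compound 2 to compound 3 (0.06 log units; within the scatter). Set against hydrogen at the same carbon, nitro gives a 1.1-fold lower number from compound 1 to compound 3 (0.06 log units; within the scatter), so hydrogen, chloro and nitro cannot be told apart here, and the flat reading now holds for two different substituents rather than one. No available evidence accounts for this flat result.

The compounds shown leave open whether an amine or a carboxylic acid on this carbon would move the number beyond the scatter. They also leave open whether any change to the shared core would do so, since all three compounds differ only at this one carbon.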